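The source may report more compounds than this note shows. Statements on the series, on what has been measured and on what is new or still open speak of the compounds shown alone.

Measured in a functional assay on T47D cells (Homo sapiens) for cytotoxicity, read by MTT assay; on this read-out higher numbers stand for weaker inhibition and lower numbers for stronger inhibition:
compound 1 `COc1cc(O)ccc1/C=C/C(=O)c1ccc(NC(C)=O)cc1`: 12300 nM
compound 2 `COc1ccc(/C=C/C(=O)c2ccc(O)cc2)cc1Br`: "not determined" (no result reported)
compound 3 `COc1ccc(C(=O)/C=C/c2ccc(OC)c(Br)c2)c(O)c1`: "not determined" (no result reported)

Among the compounds with values here, only one of these three compounds has a number. Compound 2 has no place on the scale, since its entry reads "not determined" (no result reported), and compound 3 likewise reads "not determined" (no result reported). Within the data shown here, there is therefore no measured pair that differs in a single place, and no measured step to learn from.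

The next structure is compound 4 `COc1ccc(/C=C/C(=O)c2ccc(F)cc2)cc1Br`, which is built from compound 2 by one swap: fluoro in place of hydroxy on an aromatic carbon.

With no number for compound 2, the size of this step in this assay cannot be worked out, so no shift in either direction beyond the usual scatter is expected. Among the measured compounds shown here, the only anchor is compound 1 at 12300 nM, a different structure, so the expected range must stay wide.

For compound 4 the estimated value is 15000 nM, with an expected range from 5000 nM to 50000 nM.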

Compound 4, half-maximal inhibitory concentration: > 25000 nM
Compound 4: no number, only a limit; the forecaster's own chance of this, stated with the estimate: 15%; at least 1.6-fold (0.22 log units) between middle value and limit.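

No step can be read between compound 2 and compound 4: compound 2 has no number. In this assay compound 4 gives > 25000 nM as a limit and not a number. The compounds shown leave open whether fluoro in place of hydroxy changes the cytotoxicity at all.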